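Swapping the Amine at the End of a Side Chain

The source may report more compounds than this note shows. Statements on the series, on what has been measured and on what is new or still open speak of the compounds shown alone.

Compound 2 `O=c1cc(-c2ccccc2)oc2c(OCCCN3CCCC3)c(OCc3ccccc3)cc(O)c12` was tested in a functional assay on A549 cells (Homo sapiens) for cytotoxicity, read by MTT assay, with a stated time of 72 h (on this read-out higher numbers stand for weaker inhibition and lower numbers for stronger inhibition), where compound 2 gives 4720 nM. Within the data shown here, the only other compound measured here is compound 1 `CCN(CC)CCCOc1c(OCc2ccccc2)cc(O)c2c(=O)cc(-c3ccccc3)oc12`, which in this assay gives 3620 nM. Compound 2 has the higher of the two numbers, but the step of a 1.3-fold higher number from compound 1 to compound 2 (0.12 log units; within the scatter) is too small to tell the two apart, so they count as equal on this read-out.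

Compound 3 `CN1CCN(CCCOc2c(OCc3ccccc3)cc(O)c3c(=O)cc(-c4ccccc4)oc23)CC1` has not been measured. It differs from compound 2 by 4-methylpiperazin-1-yl in place of pyrrolidin-1-yl on a saturated chain carbon, three bonds along the chain from an oxygen on an aromatic ring. Among the measured compounds shown here, this is the same kind of change as the one measured step, an exchange of the amine at the end of the side chain, and that step stayed within the scatter. The expectation is therefore a step of a 1.2-fold higher number from compound 2 to compound 3 (0.07 log units; within the scatter) that does not go beyond the scatter. For compound 3 the estimated value in this assay is 5500 nM, expected to fall between 2500 nM and 12000 nM.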

Compound 3, half-maximal inhibitory concentration: 3940 nM
The estimate for compound 3 lay 1.4-fold (0.14 log units) above the measured number, and the stated range covers the measured number.
By their numbers in this assay, from the lowest: compounds 1, 3 and 2 (each within the scatter of the next).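

Replacing the end group with 4-methylpiperazin-1-yl gives in this assay a 1.2-fold lower number from compound 2 to compound 3 (0.08 log units; within the scatter) and a 1.1-fold higher number from compound 1 to compound 3 (0.04 log units; within the scatter), so this group counts as equal to both pyrrolidin-1-yl and diethylamino. The earlier pair compared only two amines, whereas this result shows that a six-membered ring with a second nitrogen also makes no readable difference on the chain, at least among these three compounds. Nothing available here explains why these three amines read alike.

The compounds shown leave open whether a morpholin-4-yl group or a simple primary amine at the end of the same chain would also stay within the scatter. They also leave open what would happen if the 3-(4-methylpiperazin-1-yl)propyl chain were replaced by a longer butyl chain carrying the same amine.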